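The source may report more compounds than this note shows. Statements on the series, on what has been measured and on what is new or still open speak of the compounds shown alone.

In an ADME assay for permeability, using PAMPA, with a stated time of 4 h, at pH 7.4 (a lower number here means that the compound crosses the layer more slowly, a higher number that the compound crosses the layer faster), compound 3 `CN1CCN(CCCN(C[C@H]2Cc3ccccc3CN2)[C@H]2CCCc3cccnc32)CC1` gives 360 nm/s. That is within the scatter of compound 2 `c1ccc2c(c1)CN[C@@H](CN(CCCN1CCN(C3CC3)CC1)[C@H]1CCCc3cccnc31)C2` at 505 nm/s, and both lie well clear of compound 1 `c1ccc2c(c1)CN[C@@H](CN(CCN1CCNCC1)[C@H]1CCCc3cccnc31)C2` at 10 nm/s.

The next compound to read is compound 4 `c1ccc2c(c1)CN[C@@H](CN(CCCCN1CCNCC1)[C@H]1CCCc3cccnc31)C2`, which has the same atoms as compound 3, joined differently: (piperazin-1-yl)methyl in place of 4-methylpiperazin-1-yl on a saturated chain carbon, three bonds along the chain from an amine nitrogen. In words, (piperazin-1-yl)methyl stands in place of 4-methylpiperazin-1-yl on a saturated chain carbon, three bonds along the chain from an amine nitrogen. Cut one bond further out, this is 3-(4-methylpiperazin-1-yl)propyl to 4-(piperazin-1-yl)butyl.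

Within the data shown here, three measured steps bear on this change. The step of a 1.4-fold lower number from compound 2 to compound 3 (0.15 log units; within the scatter) shows no separation between the methyl and cyclopropyl substituents on the ring nitrogen. Among the measured compounds shown here, the steps of a 51-fold higher number from compound 1 to compound 2 (1.70 log units; beyond the scatter) and a 36-fold higher number from compound 1 to compound 3 (1.56 log units; beyond the scatter) are both large, and both start from compound 1, the only measured compound that, like compound 4, has no substituent on that nitrogen. For the measured compounds named here, each of these two steps changes chain and substituent together, and no measured pair separates the two changes. Compound 4 keeps the longer chain but loses the substituent, so a large fall from compound 3 is expected, probably stopping short of the full size of those steps.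

The expected change is a 9.0-fold lower number from compound 3 to compound 4 (0.95 log units; beyond the scatter). For compound 4 the estimate is 40 nm/s, with an expected range of 10 nm/s to 160 nm/s.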

Compound 4, apparent permeability: 14 nm/s
Beside the measured number, compound 4's estimate is 2.9-fold (0.46 log units) above it, within the range that was stated.
By their numbers in this assay, from the lowest: compounds 1 and 4 (each within the scatter of the next); then compounds 3 and 2 (each within the scatter of the next).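

In this assay, the same atoms rearranged give a 26-fold lower number from compound 3 to compound 4 (1.41 log units; beyond the scatter), and the cyclopropyl partner gives a 36-fold lower number from compound 2 to compound 4 (1.56 log units; beyond the scatter), so both compounds with a substituent on the piperazine nitrogen stand well clear of the unsubstituted 4-(piperazin-1-yl)butyl compound. Lengthening the chain while that nitrogen stays free gives a 1.4-fold higher number from compound 1 to compound 4 (0.15 log units; within the scatter), which separates the two changes that the earlier steps carried together: across these four compounds the chain change alone shows no separation, the large gaps fall between the substituted and unsubstituted piperazines, and no compound shown goes against this split. No measurement shown here explains the split.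

Methyl and cyclopropyl appear only on the propyl chain, so it remains open whether 2-(4-methylpiperazin-1-yl)ethyl or 4-(4-methylpiperazin-1-yl)butyl would sit with compound 3 or with compound 4. Also open, from the compounds shown here alone, is where a morpholin-4-yl or a 4-acetylpiperazin-1-yl group would fall in this assay.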